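The source may report more compounds than this note shows. Statements on the series, on what has been measured and on what is new or still open speak of the compounds shown alone.

In an ADME assay on MDBK cells (Bos taurus) for cytotoxicity, read by MTT assay, with a stated time of 96 h (a higher number here means that more compound is tolerated, a lower number that less compound is tolerated), compound 1 `FC(F)(F)c1cccc(NC(=S)Nc2ccc(I)cc2)c1` gives 9500 nM while compound 2 `O=[N+]([O-])c1ccc(NC(=S)Nc2cccc(C(F)(F)F)c2)cc1` gives 10000 nM and compound 3 `N#Cc1ccc(NC(=S)Nc2cccc(C(F)(F)F)c2)cc1` gives 10000 nM on the same scale. Compound 1 therefore stands level with both others, all within the scatter. Swapping the group on the aromatic carbon hardly registers: nitro for iodo gives a 1.1-fold higher number from compound 1 to compound 2 (0.02 log units; within the scatter) and cyano for iodo gives a 1.1-fold higher number from compound 1 to compound 3 (0.02 log units; within the scatter) while cyano for nitro gives no change at the digits printed from compound 2 to compound 3 (within the scatter) in the same measurement.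

Compound 4 `CSCCCNC(=S)Nc1cccc(C(F)(F)F)c1` has yet to be measured, and it differs in another place: 3-(methylsulfanyl)propyl in place of 4-iodophenyl on an amide-type nitrogen is the change, with 3-(methylsulfanyl)propyl in place of 4-iodophenyl on an amide-type nitrogen. The measured steps all keep the aromatic ring and exchange only a group on it, so they bear on this change only loosely. For the measured compounds named here, no measured compound lacks that ring, so a step beyond the scatter cannot be ruled out, and a modest rise in this assay is only a tentative expectation. The estimated step runs a 2.1-fold higher number from compound 1 to compound 4 (0.32 log units; beyond the scatter) as a loose guess. For compound 4 the estimated value is 20000 nM with an expected range from 6000 nM to 70000 nM.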

Compound 4, half-maximal cytotoxic concentration: > 100000 nM
Compound 4: a limit, no number (the forecaster's own chance of this, stated with the estimate: 25%); middle value at least 5.0-fold (0.69 log units) from the limit.
By their numbers in this assay, from the lowest: compounds 1, 2 and 3 (each within the scatter of the next). At a limit, above all of these: compound 4.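

In this assay compound 4 gives > 100000 nM, a limit of the assay and not a number. Putting 3-(methylsulfanyl)propyl in place of 4-iodophenyl on the amide-type nitrogen gives an at least 10-fold higher number from compound 1 to compound 4 (1.02 log units; beyond the scatter), so this position can shift the reading clearly, whereas the exchanges on the aromatic carbon among compound 1, compound 2 and compound 3 all stayed within the scatter. How far compound 4 really lies past that point cannot be read: the limit of > 100000 nM in this assay, at which 1 of the 4 values shown sits.

This single change removes the aromatic ring and brings in a sulfur-bearing chain at the same time, so the compounds shown do not tell which of the two matters. A plain propyl chain, a cyclohexyl ring or a longer chain carrying an amine on this nitrogen would help to separate the two.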